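A few compounds are considered here, and "the series" means these few. Any claim that something is new, unique, unknown or untested is made for them only; others in the source may bear on it.

The three measured compounds share one core and are read in a functional assay on the whole organism with Rattus norvegicus as the target, at a dose of 3 mg/kg by the oral route; a lower number here means a weaker effect, a higher number a stronger effect of the compound at the dose given. Compound 1 `COc1cc(C(=O)Nc2nn[nH]n2)nc(-c2ccccc2OC)c1` gives 68% in this assay. Compound 2 `COc1ccc(-c2cc(OC)cc(C(=O)Nc3nn[nH]n3)n2)cc1` gives 60% in this assay. Compound 3 `COc1cc(C(=O)Nc2nn[nH]n2)nc(-c2ccc(C)c(C)c2)c1` gives 82% in this assay. Among these three numbers compound 2 stands lowest, yet its gap to compound 1 is within the scatter, as the step of a number 8 percentage points lower from compound 1 to compound 2 (within the scatter) shows. The steps of a number 14 percentage points higher from compound 1 to compound 3 (beyond the scatter) and a number 22 percentage points higher from compound 2 to compound 3 (beyond the scatter) lie beyond the scatter and are modest in size.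

Compound 4 `COc1ccc(-c2cc(C)cc(C(=O)Nc3nn[nH]n3)n2)cc1` is not yet measured. It arises from compound 2 by the change (methyl in place of methoxy on an aromatic carbon). Within the data shown here, every measured step alters the aryl group attached to the core and leaves the methoxy on the core untouched, so none of them bears directly on this change; the methyl in place of methoxy at this position has no measured precedent in the set.

Lacking any step that informs the change, the account expects compound 4 to stay close to compound 2, with no change at the digits printed from compound 2 to compound 4 (within the scatter) as the expected step in this assay, not beyond the scatter. Compound 4 is therefore estimated at 60% in this assay, within a range from 42% to 78%.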

Compound 4, a percentage reported as inhibition, in the whole organism at one dose (the size of the read-out at that dose, not a potency): 43%
Beside the measured number, compound 4's estimate is 17 percentage points above it; the measured number falls inside the stated range.
By their numbers in this assay, from the lowest: compound 4; then compounds 2 and 1 (each within the scatter of the next); then compound 3.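

The position opposite the ring nitrogen, where the core carries its methoxy, had not varied in any earlier step, and all the earlier changes lay in the aryl group; this result shows that the core substituent also matters in this assay. With the 4-methoxyphenyl group held fixed, methyl in place of methoxy gives a number 17 percentage points lower from compound 2 to compound 4 (beyond the scatter), a modest step, so at this position methoxy is not interchangeable with methyl, which has one heavy atom fewer and no hydrogen-bond acceptor, though this single pair cannot say which of these differences counts, and no measurement at hand bears on why the read-out falls with this change.

The compounds shown leave open whether the same change would give a similar step with the 2-methoxyphenyl or the 3,4-dimethylphenyl group in place of the 4-methoxyphenyl group, since the pair compared here carries only the latter. They also leave open how other groups at this position would read in this assay, such as an ethoxy group, a chlorine atom or an amine, and whether anything there could match or exceed methoxy.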